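The source may report more compounds than this note shows. Statements on the series, on what has been measured and on what is new or still open speak of the compounds shown alone.

Measured compounds in a functional assay on the whole organism for inhibition, with Mus musculus as the target, with a stated time of 6 h, at a dose of 50 mg/kg by the oral route; a lower number here means less inhibition, a higher number more inhibition at the dose given (going by the name of the read-out):

- compound 1, `Cc1ccc(-c2c(S(=O)(=O)c3ccccc3)cnc3ncnn23)cc1`, gives 1.9%
- compound 2, `O=S(=O)(c1ccccc1)c1cnc2ncnn2c1-c1ccc(Br)cc1`, gives 0.9%
- compound 3, `Cc1ccc(-c2c(S(=O)(=O)c3ccccc3)cnc3cc(-c4ccc(Br)cc4)nn23)cc1`, gives 54.3%

Compound 1 and compound 2 share a core and differ only in one place: the change from compound 2 to compound 1 is methyl in place of bromo on an aromatic carbon. The step that goes with it, a number 1 percentage points higher from compound 2 to compound 1 (within the scatter), lies within the scatter, so the two values are read as the same.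

Compound 3 sits on a different core from compound 2; the difference between the two cores is not broken down here. Compound 3 stands highest of the three measured values, and its distance to compound 1 and to compound 2 is beyond the scatter in both cases.

Compound 4, `Cc1ccc(-c2cc3ncc(S(=O)(=O)c4ccccc4)c(-c4ccc(C)cc4)n3n2)cc1`, is not yet measured. Going by the values given here, it differs from compound 3 by methyl in place of bromo on an aromatic carbon, which is the same change as the one from compound 2 to compound 1, at a place described in the same words. Among the compounds with values here, the only measured instance of this change moved the read-out by a number 1 percentage points higher from compound 2 to compound 1 (within the scatter), within the scatter. The expectation therefore rests on one pair on a different core and carries that uncertainty.

Within the data shown here, for compound 4 the expected step is a number 0.7 percentage points higher from compound 3 to compound 4 (within the scatter), estimated from the one measured instance of the change, because that instance gave a number 1 percentage points higher from compound 2 to compound 1 (within the scatter). Compound 4 is expected to give 55% in this assay, estimated between 35% and 73%.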

Compound 4, a percentage reported as inhibition, in the whole organism at one dose (the size of the read-out at that dose, not a potency): 11.6%
Compound 4: middle estimate off by 43.4 percentage points, on the high side, and the stated range ends above it.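

In this assay, methyl in place of bromo on an aromatic carbon, read as 4-bromophenyl to 4-methylphenyl, gives a number 42.7 percentage points lower from compound 3 to compound 4 (beyond the scatter), a large step on the core of compound 3. The same change does not carry over as one fixed step between the two cores in this series, so the step on one core cannot stand in for the step on the other: the same change on two cores in this assay, a number 1 percentage points higher (within the scatter) from compound 2 to compound 1 and a number 42.7 percentage points lower (beyond the scatter) from compound 3 to compound 4, 43.7 percentage points apart, beyond the scatter of two such steps This shows only that the size of the step depends on the core in these two pairs; with one pair per core, it gives no cause for the difference, no general rule for other cores, and no potency, since the read-out comes from a single dose and time.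

On these data alone, it remains open whether the higher value of compound 3 is specific to bromo or would also be seen with another group in that place, such as chloro, methoxy or trifluoromethyl. Also open, as far as these compounds go, is how the core of compound 3 responds to changes elsewhere, for example an amine or a carboxylic acid on the 4-methylphenyl group shared by compound 3 and compound 4.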